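Anilino swap on the shared core: outlook for compound 4

The source may report more compounds than this note shows. Statements on the series, on what has been measured and on what is new or still open speak of the compounds shown alone.

Three analogues of the shared core differ only in the group carried on the anilino nitrogen. Compound 1 `CN(c1cccc2c1CN(c1nc(Nc3ccc(Nc4ccccc4)cc3)ncc1C(F)(F)F)C2)S(C)(=O)=O` gives 8600 nM in a functional assay on HepG2 cells (Homo sapiens) for antiproliferative activity, read by spectrophotometry, with a stated time of 2 days; on this read-out higher numbers stand for weaker inhibition of growth and lower numbers for stronger inhibition of growth. Compound 2 `Cc1cc(F)ccc1Nc1ncc(C(F)(F)F)c(N2Cc3cccc(N(C)S(C)(=O)=O)c3C2)n1` gives 16800 nM in this assay, and compound 3 `COc1cc(Nc2ncc(C(F)(F)F)c(N3Cc4cccc(N(C)S(C)(=O)=O)c4C3)n2)cc(C(F)(F)F)c1` gives 22100 nM. Compound 2 sits second highest of the three numbers; compound 3 is its nearest neighbour and compound 1 its furthest, and both separations fall within the scatter, so no ordering among the three is claimed. For the measured compounds named here, the one single-point step among them is a 1.3-fold higher number from compound 2 to compound 3 (0.12 log units; within the scatter).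

Compound 4 `CN(c1cccc2c1CN(c1nc(Nc3cc(Cl)cc(C(F)(F)F)c3)ncc1C(F)(F)F)C2)S(C)(=O)=O` is not yet measured. It differs from compound 2 in one place: 3-chloro-5-(trifluoromethyl)phenyl in place of 4-fluoro-2-methylphenyl on a nitrogen on an aromatic ring. Going by the values given here, the only measured step that bears on this is the one from compound 2 to compound 3, where another 3,5-substituted phenyl, 3-methoxy-5-(trifluoromethyl)phenyl, took the place of the same 4-fluoro-2-methylphenyl on the same nitrogen; that step, a 1.3-fold higher number from compound 2 to compound 3 (0.12 log units; within the scatter), stayed within the scatter. On this basis the change to compound 4 is expected to read as a 1.1-fold higher number from compound 2 to compound 4 (0.05 log units; within the scatter), again within the scatter. For compound 4 the estimate in this assay is 19000 nM, with a range from 9000 nM to 40000 nM.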

Compound 4, concentration for 50% growth inhibition: 9900 nM
Beside the measured number, compound 4's estimate is 1.9-fold (0.28 log units) above it; the range from low to high includes it.
By their numbers in this assay, from the lowest: compounds 1, 4, 2 and 3 (each within the scatter of the next, the first and the last beyond it).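

In this assay, a 1.7-fold lower number from compound 2 to compound 4 (0.23 log units; within the scatter) shows that a second exchange of the whole aryl group on this nitrogen, now for 3-chloro-5-(trifluoromethyl)phenyl, also stays within the scatter, even with the larger entering group. For the compounds shown here, the new information comes from the pair that keeps the trifluoromethyl group and carries chloro in place of methoxy on an aromatic carbon: a 2.2-fold lower number from compound 3 to compound 4 (0.35 log units; beyond the scatter) is the only step printed as beyond the scatter. The read-out at this position can therefore shift with one substituent on the aryl group, although this rests on a single modest step between one pair of compounds, and no data shown here explain it.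

The compounds shown leave open whether other groups in place of chloro, such as a nitrile, an amine or a carboxylic acid, would extend this step or reverse it. On these data alone, it is also open whether the same exchange of chloro for methoxy would give a similar step if a methyl group or a bare hydrogen stood in place of the trifluoromethyl group on the same aryl ring.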